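Methyl for Hydrogen on the Fused Ring of Compound 2

This account rests on a few compounds, and the source may have more. Where it says the series, first, only, none or still open, it means among the compounds named here.

Measured compounds:
compound 1 `COc1ccc2nc(Cl)c(Cn3cc(CN4c5ccccc5C(C)=CC4(C)C)nn3)cc2c1`, 38700 nM
compound 2 `CC1=CC(C)(C)N(Cc2cn(Cc3cc4ccccc4nc3Cl)nn2)c2ccccc21`, 16200 nM
compound 3 `COc1ccc2c(c1)C(C)=CC(C)(C)N2Cc1cn(Cc2cc3cc(OC)ccc3nc2Cl)nn1`, 26400 nM

In a functional assay on MCF7 cells (Homo sapiens) for cytotoxicity, read by MTT assay, with a stated time of 48 h (on this read-out lower numbers stand for stronger inhibition and higher numbers for weaker inhibition), compound 2 gives 16200 nM, which is the smallest of the three numbers. Among the compounds with values here, its separation from compound 3 is within the scatter, so the two cannot be ranked; only the step of a 2.4-fold lower number from compound 1 to compound 2 (0.38 log units; beyond the scatter) is beyond the scatter, and that step was a modest one for the loss of a methoxy on an aromatic carbon. The other step, a 1.5-fold lower number from compound 1 to compound 3 (0.17 log units; within the scatter), stayed within the scatter.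

Compound 4 `CC1=CC(C)(C)N(Cc2cn(Cc3cc4ccc(C)cc4nc3Cl)nn2)c2ccccc21` is compound 2 with methyl in place of hydrogen on an aromatic carbon. Within the data shown here, no compound here carries a methyl on an aromatic carbon, so the two steps bear on it only loosely: both show that a single small group on an aromatic carbon of a fused system moved the number by little, and the one change beyond the scatter went in the direction of a lower number when a group was removed rather than added. Compound 4 is therefore expected to sit close to compound 2, with a step of a 1.1-fold lower number from compound 2 to compound 4 (0.03 log units; within the scatter) not beyond the scatter. The estimate for compound 4 is 15000 nM, within 6000 nM to 38000 nM.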

Compound 4, half-maximal inhibitory concentration: 10800 nM
For compound 4 the middle estimate is 1.4-fold (0.14 log units) above the measured one, within the range that was stated.
By their numbers in this assay, from the lowest: compounds 4, 2, 3 and 1 (each within the scatter of the next, the first and the last beyond it).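

In this assay, the methyl on an aromatic carbon of the fused system of two rings, meta to a fused ring and para to a fused ring, gives a 1.5-fold lower number from compound 2 to compound 4 (0.18 log units; within the scatter), so compound 2 and compound 4 cannot be ranked. The earlier steps shown here concerned only methoxy, whereas this one shows that a single carbon at this position, the group entering with 1 heavy atom, no hydrogen-bond donors and no hydrogen-bond acceptors, leaves the number within the scatter of the hydrogen compound, with no measurable gain or loss. No accompanying measurement bears on this result, so the step stands here without an explanation.

The compounds shown leave open whether anything placed at this carbon can move the number beyond the scatter, for example an amine, a carboxylic acid, a fluorine atom or a longer chain such as propyl. They also leave open whether a methyl on the other ring carbons of the fused system would behave as it does here, since this single step speaks for one position only.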